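The compounds below may be only part of what the source reports. "The series", "measured", "known", "first", "only" and "open" are said of these compounds alone.

Compound 3 `Cc1nn(C)c(Oc2cccc(F)c2F)c1/C=N\CCCCCCOc1cc2oc(=O)cc(C)c2cc1Cl` is one of three close relatives tested in a functional assay on HepG2 cells (Homo sapiens) for antiproliferative activity, read by MTT assay, with a stated time of 72 h; on this read-out higher numbers stand for weaker inhibition and lower numbers for stronger inhibition. In this assay compound 3 gives only a limit, > 25000 nM, and no number. Compound 1 `Cc1nn(C)c(Oc2ccc(F)cc2)c1/C=N\CCCCCOc1cc2oc(=O)cc(C)c2cc1Cl` likewise reaches only the limit, > 25000 nM, in this assay. Compound 2 `Cc1nn(C)c(Oc2ccc(I)cc2)c1/C=N\CCCCCOc1cc2oc(=O)cc(C)c2cc1Cl` also stops at the limit, giving > 25000 nM in this assay. All three values sit at the limit of > 25000 nM in this assay, at which 3 of the 3 values shown sit, so compound 3 cannot be placed higher or lower than its companions on the numbers shown. Compound 4 `Cc1nn(C)c(Oc2ccc(I)cc2)c1/C=N\CCCCCCOc1cc2oc(=O)cc(C)c2cc1Cl` has not yet been measured in this assay. It differs from compound 3 in one place: 4-iodophenyl in place of 2,3-difluorophenyl on an oxygen on an aromatic ring. The closest measured guide is the exchange of fluoro for iodo on an aromatic carbon, which reads a step that the two limits leave unreadable from compound 1 to compound 2; its size is hidden. With every related value resting at the limit, compound 4 is expected to give in this assay an estimated 30000 nM, with a range from 12000 nM to 100000 nM. The expected step is therefore a step that the limit leaves unreadable from compound 3 to compound 4, nothing readable beyond the scatter.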

Compound 4, half-maximal inhibitory concentration: 14200 nM
The estimate for compound 4 lay 2.1-fold (0.32 log units) above the measured number; the range from low to high includes it.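

Swapping 2,3-difluorophenyl for 4-iodophenyl on the oxygen gives an at least 1.7-fold lower number from compound 3 to compound 4 (0.24 log units; that floor lies within the scatter) in this assay and is the first change here that can be sized at all. Compound 4 is the only one of the four compounds shown with a real number rather than a limit, so this position can carry a group that brings the value into the measurable range, even though the floor of the step does not clear the usual scatter. The step from compound 1 to compound 2 cannot be read, and most values still give no number: the limit of > 25000 nM in this assay, at which 3 of the 4 values shown sit.

Compound 2, with the same 4-iodophenyl on a shorter chain, stops at the limit > 25000 nM and so leaves open how much the chain contributes. Also open, as far as these compounds go, is whether a longer chain, or an amine or carboxylic acid in place of the iodo, would lower the number further.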